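From Amino to 2,5-Dioxopyrrolidin-1-yl on a Shared Core

The source may hold more compounds than are shown below. What is called first, only, known or untested is meant among the compounds shown, and "the series" means these compounds.

Compound 1 `N#CC1=C(N)N(c2ccc(S(N)(=O)=O)cc2)C2=C(C(=O)CCC2)C1c1ccc(Cl)cc1Cl` was tested in a functional assay on Ehrlich cells (Mus musculus) for cytotoxicity, read by trypan blue exclusion, with a stated time of 2 h, tested at 100 ug/mL (a higher number here means a stronger effect of the compound at the concentration tested, a lower number a weaker effect), where compound 1 gives 95%. Among the three numbers shown, compound 1 stands second highest, with compound 2 `N#CC1=C(NC(=S)Nc2ccc(Cl)cc2)N(c2ccc(S(N)(=O)=O)cc2)C2=C(C(=O)CCC2)C1c1ccc(Cl)cc1Cl` nearest at 100% and compound 3 `N#CC1=C(NC(=S)Nc2ccc(Br)cc2)N(c2ccc(S(N)(=O)=O)cc2)C2=C(C(=O)CCC2)C1c1ccc(Cl)cc1Cl` furthest at 90%. The step of a number 5 percentage points higher from compound 1 to compound 2 (within the scatter) and the step of a number 5 percentage points lower from compound 1 to compound 3 (within the scatter) both stay within the scatter, as does the step of a number 10 percentage points lower from compound 2 to compound 3 (within the scatter), so the three measured compounds cannot be told apart on this read-out.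

Compound 4 `N#CC1=C(N2C(=O)CCC2=O)N(c2ccc(S(N)(=O)=O)cc2)C2=C(C(=O)CCC2)C1c1ccc(Cl)cc1Cl` is not yet measured. It differs from compound 1 by 2,5-dioxopyrrolidin-1-yl in place of amino on a double-bonded ring carbon. The measured steps that bear on this site are those from compound 1 to compound 2 and from compound 1 to compound 3: each replaces a hydrogen atom on the amine nitrogen, whereas the change to compound 4 removes the amino group altogether. Among the measured compounds shown here, since neither of those steps moved the read-out beyond the scatter, and since every number so far sits near the top of the scale, no step beyond the scatter is expected here either. Compound 4 is therefore expected to give 90%, within 70% to 100%. That estimate means a step of a number 5 percentage points lower from compound 1 to compound 4 (within the scatter), which is expected to remain within the scatter.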

Compound 4, a percentage reported as activity, at one concentration (the size of the read-out at that concentration, not a potency): 90%
For compound 4 middle estimate and measured number coincide at the digits printed; the range from low to high includes it.
By their numbers in this assay, from the lowest: compounds 3, 4, 1 and 2 (each within the scatter of the next).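

Earlier steps only added to the amine nitrogen, whereas here the amino group itself gives way to 2,5-dioxopyrrolidin-1-yl, a group with no hydrogen-bond donor, and this assay shows a number 5 percentage points lower from compound 1 to compound 4 (within the scatter) for that exchange. The comparisons with the two larger groups at this double-bonded ring carbon read no change at the digits printed from compound 3 to compound 4 (within the scatter) and a number 10 percentage points lower from compound 2 to compound 4 (within the scatter), so the four compounds remain indistinguishable on this read-out, and neither the hydrogen-bond donor of the amino group nor the aromatic ring of the larger groups is shown to be needed for the effect seen at this single concentration. Nothing given here offers an explanation for this result.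

As far as these compounds go, what remains open is whether any change at this carbon can separate the compounds at all, since every number so far lies close to the top of the scale, and lower concentrations might reveal differences that a single high concentration cannot. From the compounds shown here alone, it is equally open whether an open-chain acetamide, a carboxylic acid or a longer alkyl chain on the amine nitrogen would give a step beyond the scatter from compound 1.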